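This account rests on a few compounds, and the source may have more. Where it says the series, first, only, none or still open, it means among the compounds named here.

Three compounds share one core and differ only in the group on a saturated ring carbon: compound 1 `CCC1CN(c2ccccc2)NC(=O)N1`, compound 2 `CC(C)C1CN(c2ccccc2)NC(=O)N1` and compound 3 `CCCCC1CN(c2ccccc2)NC(=O)N1`. In an assay on RBL-1 cells for inhibition of Polyunsaturated fatty acid 5-lipoxygenase (Rattus norvegicus) (a higher number here means a weaker inhibitor, a lower number a stronger inhibitor), compound 1 gives 6900 nM, compound 2 gives 6800 nM and compound 3 gives 1500 nM, the lowest of the three. The steps of a 4.6-fold lower number from compound 1 to compound 3 (0.66 log units; beyond the scatter) and a 4.5-fold lower number from compound 2 to compound 3 (0.66 log units; beyond the scatter) show that the longer chain goes with the lower number, whereas between compound 1 and compound 2 the step is a 1.0-fold lower number from compound 1 to compound 2 (0.01 log units; within the scatter). Compound 4 `O=C1NC(CO)CN(c2ccccc2)N1` goes the other way: hydroxy in place of propyl on a saturated chain carbon bound to a saturated ring carbon. Going by the values given here, no measured step brings in a hydroxy, but the two chain steps suggest that cutting the chain back should raise the number, so compound 4 is expected to show a 5.3-fold higher number from compound 3 to compound 4 (0.73 log units; beyond the scatter) in this assay. Compound 4 is therefore estimated at 8000 nM, within 2500 nM to 25000 nM.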

Compound 4, half-maximal inhibitory concentration: 40000 nM
For compound 4 the middle estimate is 5.0-fold (0.70 log units) below the measured one; measured number outside the range, above it.
By their numbers in this assay, from the lowest: compound 3; then compounds 2 and 1 (each within the scatter of the next); then compound 4.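

Swapping a carbon for an oxygen at this place matters even when chain length barely changes: in this assay, hydroxy in place of methyl gives a 5.8-fold higher number from compound 1 to compound 4 (0.76 log units; beyond the scatter). Against the branched isopropyl group, hydroxymethyl gives a 5.9-fold higher number from compound 2 to compound 4 (0.77 log units; beyond the scatter), and against the longest chain the hydroxy change gives a 27-fold higher number from compound 3 to compound 4 (1.43 log units; beyond the scatter), so this position responds to more than chain length. No measurement here explains why the hydroxy raises the number.

From the compounds shown here alone, whether a methoxy or an amine at this place would behave like the hydroxy remains open. So does whether a chain longer than butyl would lower the number further.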